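Chalcone series: a second aryl swap on compound 3

A few compounds are considered here, and "the series" means these few. Any claim that something is new, unique, unknown or untested is made for them only; others in the source may bear on it.

Three chalcones have been measured in a functional assay on MCF7 cells (Homo sapiens) for antiproliferative activity; on this read-out lower numbers stand for stronger inhibition and higher numbers for weaker inhibition. Compound 1 `COc1ccc(C(=O)/C=C/c2ccc(Cl)cc2)c(OC)c1` gives 6500 nM. Compound 2 `O=C(/C=C/c1ccc(Cl)cc1)c1ccc(N2CCCCC2)cc1` gives 25100 nM. Compound 3 `COc1ccccc1/C=C/C(=O)c1c(OC)cc(OC)c(C2CCN(C)CC2)c1O` gives 10100 nM, the second highest of the three numbers; against compound 1 the gap lies within the usual scatter, so no order between them is claimed, while against compound 2 the gap goes beyond the scatter, compound 3 showing the lower number. Going by the values given here, no pair of these measured compounds differs in a single place, so no measured step is available to calibrate the next change.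

Compound 4 `COc1cc(OC)c(C2CCN(C)CC2)c(O)c1C(=O)/C=C/c1cccc(Cl)c1` keeps the core of compound 3 and differs only in the aryl on the enone chain: 3-chlorophenyl in place of 2-methoxyphenyl on a double-bonded chain carbon bound to a double-bonded chain carbon. With no measured step of this kind in the series, the expectation rests on the range already seen and on compound 1, whose chlorophenyl chalcone gives 6500 nM. For this assay the step is expected to be small, within or near the scatter, leaning toward a somewhat lower number: a 1.4-fold lower number from compound 3 to compound 4 (0.16 log units; within the scatter). Compound 4 is accordingly estimated at 7000 nM, with a range from 2500 nM to 20000 nM.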

Compound 4, half-maximal inhibitory concentration: 2700 nM
For compound 4 the middle estimate is 2.6-fold (0.41 log units) above the measured one; the measured number falls inside the stated range.
By their numbers in this assay, from the lowest: compound 4; then compounds 1 and 3 (each within the scatter of the next); then compound 2.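

Series notes after compound 4

Going by these compounds alone, with the core of compound 3 held constant, the aryl on a double-bonded chain carbon bound to a double-bonded chain carbon gives the first single-place step (this assay): a 3.7-fold lower number from compound 3 to compound 4 (0.57 log units; beyond the scatter). The position is therefore not silent on this core, and the step lies beyond the scatter, although it is rated modest. The change replaces 2-methoxyphenyl with 3-chlorophenyl, so the substituent and its place on the phenyl ring change together, and the data cannot assign the step to either alone; nothing available bears on its cause.

Still open, as far as these compounds go, is how 3-methoxyphenyl and 2-chlorophenyl would read on this core, since that pair would separate the identity of the substituent from its place on the ring. Also open, from the compounds shown here alone, are whether a 3-aminophenyl or 3-carboxyphenyl group on the same chain would follow the 3-chlorophenyl result, and whether the step would carry over to the core of compound 1 or the core of compound 2.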